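Swapping a dichloropyridine for a dichlorophenyl ring

The compounds below may be only part of what the source reports. "The series", "measured", "known", "first", "only" and "open" are said of these compounds alone.

Measured so far:
- compound 1, `COc1cc(CNCc2ccncc2)ccc1OCc1cnc(Cl)c(Cl)c1`, in a functional assay on HeLa cells (Homo sapiens) for inhibition, with a stated time of 72 h (on this read-out lower numbers stand for an effect already at smaller amounts and higher numbers for an effect only at larger amounts of compound), compound 1 gives 220 nM
- compound 2, `COc1cc(CNc2nc[nH]n2)ccc1OCc1ccc(Cl)nc1`, in this assay compound 2 gives 69000 nM

Compound 1 stands at the lower of the two numbers in this assay; compound 2 is far away from it, and the two compounds differ in more than one place, so their values can only be set side by side without assigning the gap to any single change. Within the data shown here, no pair of compounds differing in just one place has been measured.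

Compound 3, `COc1cc(CNCc2ccncc2)ccc1OCc1ccc(Cl)cc1Cl`, has not yet been measured. It is reached from compound 1 by the change (2,4-dichlorophenyl in place of 5,6-dichloropyridin-3-yl on a saturated chain carbon bound to an oxygen on an aromatic ring). Among the measured compounds shown here, since no measured pair speaks to this kind of exchange, the expectation rests only on compound 1, whose value 220 nM is taken as the anchor, and the step of a 1.4-fold higher number from compound 1 to compound 3 (0.13 log units; within the scatter) is estimated to lie within the scatter or a little beyond it, in either direction. On that basis compound 3 is expected to give about 300 nM in this assay, with a range from 80 nM to 1200 nM.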

Compound 3, half-maximal effective concentration: 3900 nM
Compound 3: middle estimate off by 13-fold (1.11 log units), on the low side, outside the stated range (above it).
By their numbers in this assay, from the lowest: compound 1; then compound 3; then compound 2.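

Among these compounds, this is the first pair that differs in only one place, and it shows that this assay responds strongly to the group on the saturated chain carbon bound to an oxygen on an aromatic ring: an 18-fold higher number from compound 1 to compound 3 (1.25 log units; beyond the scatter). The two groups match in size, each with 8 heavy atoms including 2 chlorine, so the shift accompanies an exchange that leaves the count unchanged but replaces the ring nitrogen with carbon, removes the single hydrogen-bond acceptor and, as the names 5,6-dichloropyridin-3-yl and 2,4-dichlorophenyl show, alters the chlorine arrangement. Nothing available explains why this exchange carries such a large step.

Because the ring nitrogen and the chlorine arrangement change together in this one pair, the compounds shown cannot separate their contributions. They also leave open how this assay would respond to a pyridine ring without chlorine or to a trifluoromethyl group in place of the chlorines, and whether the step would be of similar size on a different core.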